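A few compounds are considered here, and "the series" means these few. Any claim that something is new, unique, unknown or untested is made for them only; others in the source may bear on it.

In a functional assay on cells (Erythrocyte, Rattus norvegicus) for inhibition, read by hemolysis, with a stated time of 1 h (on this read-out higher numbers stand for weaker inhibition and lower numbers for stronger inhibition), compound 1 `COc1cc(OC)c(OC)cc1/C=C/C(=O)c1ccc(Cl)cc1` gives 2.3 ug/mL and compound 2 `COc1cc(OC)c(OC)cc1/C=C/C(=O)c1ccccc1` gives 2.23 ug/mL, so compound 2 stands level with compound 1 within the scatter. Compound 3 `COc1cc(OC)c(OC)cc1/C=C/C(=O)c1ccc(-c2c[nH]cn2)cc1` differs from compound 2 by 1H-imidazol-4-yl in place of hydrogen on an aromatic carbon, with 1H-imidazol-4-yl in place of hydrogen. Within the data shown here, the only measured step at that place is a 1.0-fold lower number from compound 1 to compound 2 (0.01 log units; within the scatter), hydrogen in place of chloro, and it lies within the scatter. Among the measured compounds shown here, no measured step involves a ring there, so no direction is supported and none beyond the scatter is expected. The expected change is a 1.1-fold higher number from compound 2 to compound 3 (0.05 log units; within the scatter). For compound 3 the estimate is 2.5 ug/mL, with an expected range from 1 ug/mL to 6 ug/mL.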

Compound 3, half-maximal inhibitory concentration: 2.48 ug/mL
For compound 3 the middle estimate is 1.0-fold (0.00 log units) above the measured one; measured number inside the range.
By their numbers in this assay, from the lowest: compounds 2, 1 and 3 (each within the scatter of the next).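

In this assay, the aromatic carbon para to a large group accepts a whole 1H-imidazol-4-yl ring with no step beyond the scatter: a 1.1-fold higher number from compound 2 to compound 3 (0.05 log units; within the scatter) and a 1.1-fold higher number from compound 1 to compound 3 (0.03 log units; within the scatter). The earlier pair covered only hydrogen and chloro, whereas this change brings in 5 heavy atoms and a five-membered aromatic ring with 2 hetero atoms. Nothing available explains why the number holds level here.

From the compounds shown here alone, whether an amine, a carboxylic acid or a longer chain at this carbon would give a step beyond the scatter remains open. So does whether any other place on the shared core would respond to change.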